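Working notes: chloro to trifluoromethyl swap on compound 2

The source may hold more compounds than are shown below. What is called first, only, known or untested is meant among the compounds shown, and "the series" means these compounds.

compound 1 `CC1=CC(C)(C)N(Cc2cccc(C(F)(F)F)c2)c2ccc(OCc3cccc(C(F)(F)F)c3)cc21` | > 180000 nM | a limit of the assay
compound 2 `CC(=O)Oc1ccc2c(c1)C(C)=CC(C)(C)N2Cc1cccc(Cl)c1` | 29000 nM | a number

Within the data shown here, in an ADME assay on L6 cells (Rattus norvegicus) for cytotoxicity, read by resazurin assay, with a stated time of 70 h (a lower number here means a stronger inhibitor, a higher number a weaker inhibitor), compound 2 gives 29000 nM as the only number so far, so it has no measured neighbour to be ranked against. Compound 1 reports > 180000 nM as a limit and not a number.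

Compound 3 `CC(=O)Oc1ccc2c(c1)C(C)=CC(C)(C)N2Cc1cccc(C(F)(F)F)c1` differs from compound 2 in one place, with trifluoromethyl in place of chloro on an aromatic carbon as the counted change: trifluoromethyl in place of chloro on an aromatic carbon, meta to a large group. The rest of the structure stays the same.

Among the measured compounds shown here, no measured pair shows what this swap does, so the expectation starts from compound 2 at 29000 nM and assumes no direction. No step beyond the usual scatter is expected in this assay, and the estimated change is a 1.0-fold higher number from compound 2 to compound 3 (0.01 log units; within the scatter) on that reading. Compound 3 is estimated at 30000 nM with 12000 nM to 80000 nM as the expected range.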

Compound 3, half-maximal inhibitory concentration: 27000 nM
Compound 3: the middle estimate sits 1.1-fold (0.05 log units) above what was measured; measured number inside the range.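

In this assay, trifluoromethyl in place of chloro on an aromatic carbon, meta to a large group, gives a 1.1-fold lower number from compound 2 to compound 3 (0.03 log units; within the scatter), so compound 2 and compound 3 cannot be told apart at this position, and this one swap gives no sign that the read-out depends on which of the two groups sits there. The oxygen on the aromatic ring is where a readable step appears, with acetyl in place of 3-(trifluoromethyl)benzyl giving an at least 6.6-fold lower number from compound 1 to compound 3 (0.82 log units; beyond the scatter). Compound 1 stands at a limit and not at a number, so this step gives only a bound and not a size: the limit of > 180000 nM in this assay, at which 1 of the 3 values shown sits.

The compounds shown leave open what an amine or a carboxylic acid on the same aromatic carbon would give in this assay, since the only two groups seen there are chloro and trifluoromethyl. Also open, on these data alone, is what a free hydroxyl or a longer ester chain on the oxygen would give, which would show whether the step on that oxygen extends beyond the acetyl and 3-(trifluoromethyl)benzyl pair.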